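Thiourea series: chloro for fluoro on the anilide ring

The source may hold more compounds than are shown below. What is called first, only, known or untested is meant among the compounds shown, and "the series" means these compounds.

Measured so far:
compound 1 `O=C(NC(=S)Nc1ccc(F)cc1)c1cn(-c2ccccc2)nc1-c1ccccc1` — 3500 nM
compound 2 `COc1ccc(-c2nn(-c3ccccc3)cc2C(=O)NC(=S)Nc2ccc(F)cc2)cc1` — 1430 nM
compound 3 `O=C(NC(=S)Nc1ccc(F)cc1)c1cn(-c2ccccc2)nc1-c1ccc(F)cc1` — 3540 nM

In a functional assay on A549 cells (Homo sapiens) for inhibition, read by CCK-8 assay, with a stated time of 48 h (on this read-out lower numbers stand for stronger inhibition and higher numbers for weaker inhibition), compound 2 gives the lowest number of the three; the nearest is compound 1 with a 2.4-fold lower number from compound 1 to compound 2 (0.39 log units; beyond the scatter) reversed, and compound 3 lies further, with a 2.5-fold higher number from compound 2 to compound 3 (0.39 log units; beyond the scatter). Compound 1 and compound 3 sit within the scatter of each other, as a 1.0-fold higher number from compound 1 to compound 3 (0.00 log units; within the scatter) shows.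

Compound 4 `COc1ccc(-c2nn(-c3ccccc3)cc2C(=O)NC(=S)Nc2ccc(Cl)cc2)cc1` differs from compound 2 by chloro in place of fluoro on an aromatic carbon. Among the measured compounds shown here, the three measured steps all concern the other aryl ring (methoxy or fluoro in place of hydrogen); none touches the ring that carries the fluoro here, so no measured step bears directly on this change. With nothing to point either way, the expected step in this assay is a 1.0-fold higher number from compound 2 to compound 4 (0.02 log units; within the scatter), that is no change beyond the scatter, with a wide range to reflect the lack of a precedent. Compound 4 is therefore estimated at 1500 nM, between 600 nM and 3800 nM.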

Compound 4, half-maximal inhibitory concentration: 1310 nM
Estimate against measurement, compound 4: 1.1-fold (0.06 log units) above; low and high end bracket the measured number.
By their numbers in this assay, from the lowest: compounds 4 and 2 (each within the scatter of the next); then compounds 1 and 3 (each within the scatter of the next).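

Within the series, the only step shown on the anilide ring is chloro in place of fluoro, para to a large group. In this assay, among the compounds shown here, it gives a 1.1-fold lower number from compound 2 to compound 4 (0.04 log units; within the scatter), so on the core of compound 2 the two halogens cannot be told apart at this position, whereas the earlier steps concerned only the other aryl ring, where methoxy in place of hydrogen gave a 2.4-fold lower number from compound 1 to compound 2 (0.39 log units; beyond the scatter). No evidence at hand bears on this result.

Still open, as far as these compounds go, is whether a group other than a halogen at this position, such as an amine, a carboxylic acid or a longer alkyl chain, would move the number beyond the scatter. Also open, from the compounds shown here alone, is whether chloro in place of fluoro gives the same result on the cores of compound 1 and compound 3.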